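This account rests on a few compounds, and the source may have more. Where it says the series, first, only, none or still open, it means among the compounds named here.

Measured so far in a functional assay on HSG cells (Homo sapiens) for cytotoxicity; on this read-out higher numbers stand for lower toxicity in this test and lower numbers for higher toxicity in this test:
- compound 1 `COc1cc(/C=C2\CCC/C(=C\c3ccc([N+](=O)[O-])cc3)C2=O)ccc1O` gives 11000 nM
- compound 2 `COc1ccc(/C=C2\CCC/C(=C\c3ccc([N+](=O)[O-])cc3)C2=O)cc1OC` gives 13000 nM

Among the compounds with values here, compound 1 stands lowest of the two numbers, with compound 2 nearest; the only measured step, a 1.2-fold higher number from compound 1 to compound 2 (0.07 log units; within the scatter), changes a single methyl on an oxygen and stays within the scatter. Compound 3 `O=C1/C(=C/c2ccc(Cl)cc2)CCC/C1=C\c1ccc([N+](=O)[O-])cc1` differs from compound 1 by 4-chlorophenyl in place of 4-hydroxy-3-methoxyphenyl on a double-bonded chain carbon bound to a double-bonded ring carbon. No measured step exchanges a whole aromatic group, so nothing shown bears directly on this change, and the lone step, being within the scatter, gives no direction. Compound 3 is therefore expected near compound 1, a step of a 1.1-fold lower number from compound 1 to compound 3 (0.04 log units; within the scatter) at most, with an estimate of 10000 nM and a likely range from 3000 nM to 35000 nM.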

Compound 3, half-maximal cytotoxic concentration: 15000 nM
For compound 3 the middle estimate is 1.5-fold (0.18 log units) below the measured one; the measured number falls inside the stated range.
By their numbers in this assay, from the lowest: compounds 1, 2 and 3 (each within the scatter of the next).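

On a double-bonded chain carbon bound to a double-bonded ring carbon, 4-chlorophenyl in place of 4-hydroxy-3-methoxyphenyl gives a 1.4-fold higher number from compound 1 to compound 3 (0.13 log units; within the scatter) in this assay. Within the data shown here, this is the first whole-group exchange here: the entering group has no hydrogen-bond donors or acceptors, yet the number stays within the scatter. No supporting measurement explains this result. From the compounds shown here alone, whether an amine or a carboxylic acid on the aromatic ring at this place would move the number beyond the scatter remains open.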